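Nitrophenyl replaces chlorofluorophenyl on the sulfonamide

The source may report more compounds than this note shows. Statements on the series, on what has been measured and on what is new or still open speak of the compounds shown alone.

Four compounds share one core and differ only in the group attached to the sulfonyl sulfur. Compound 1 `Cc1ccc(S(=O)(=O)NCc2cn(Cc3cc(=O)oc4cc(O)ccc34)nn2)cc1` carries a 4-methylphenyl group, compound 2 `O=c1cc(Cn2cc(CNS(=O)(=O)c3ccc(Cl)cc3)nn2)c2ccc(O)cc2o1` a 4-chlorophenyl group, and compound 3 `O=c1cc(Cn2cc(CNS(=O)(=O)c3ccc(F)cc3Cl)nn2)c2ccc(O)cc2o1` a 2-chloro-4-fluorophenyl group. In a functional assay on CFPAC-1 cells (Homo sapiens) for inhibition, read by MTT assay, with a stated time of 72 h (a higher number here means a weaker inhibitor, a lower number a stronger inhibitor), compound 1 gives 68900 nM and compound 2 gives 81900 nM. For compound 3 the this assay reports only a limit, > 100000 nM, so no number is known for it. The three compounds lie close together: a 1.2-fold higher number from compound 1 to compound 2 (0.08 log units; within the scatter), an at least 1.4-fold higher number from compound 1 to compound 3 (0.16 log units; that floor lies within the scatter) and an at least 1.2-fold higher number from compound 2 to compound 3 (0.08 log units; that floor lies within the scatter). Compound 3 sits at the limit of > 100000 nM in this assay, at which 1 of the 3 values shown sits, which leaves the size of any step from it open-ended.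

Compound 4 `O=c1cc(Cn2cc(CNS(=O)(=O)c3ccc([N+](=O)[O-])cc3)nn2)c2ccc(O)cc2o1` differs from compound 3 in one place: 4-nitrophenyl in place of 2-chloro-4-fluorophenyl on a sulfonyl sulfur. Every measured step here exchanges the group on the sulfonyl sulfur, and none of them moves the number beyond the scatter, so the same kind of exchange is expected to give a step within the scatter, with no direction favoured. Compound 4 is therefore estimated at about 100000 nM, between 50000 nM and 200000 nM. That estimate corresponds to an expected step of a number no higher from compound 3 to compound 4 (the limit leaves the size open). A second limit instead of a number is quite possible for compound 4.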

Compound 4, half-maximal inhibitory concentration: > 100000 nM
Compound 4: only a limit was reported; the forecaster's own chance of this, stated with the estimate: 55%; the middle value sits exactly at the limit.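

In this assay compound 4 gives > 100000 nM, which is a limit and not a number, so a second group on the sulfonyl sulfur now ends at the same ceiling: the limit of > 100000 nM in this assay, at which 2 of the 4 values shown sit. Set against the compounds with actual numbers, the nitro group gives an at least 1.2-fold higher number from compound 2 to compound 4 (0.08 log units; that floor lies within the scatter) and an at least 1.4-fold higher number from compound 1 to compound 4 (0.16 log units; that floor lies within the scatter); both are only floors, so the real steps could be larger, but what can be read so far does not go beyond the scatter. The step from compound 3 to compound 4 cannot be read at all, and across the four compounds no exchange on this sulfur has yet produced a step beyond the scatter in either direction.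

On these data alone, how far compound 3 and compound 4 really lie past the limit stays open, and with it whether the 4-nitrophenyl and 2-chloro-4-fluorophenyl groups differ at all. Also open, as far as these compounds go, is whether an amine or a carboxylic acid in place of nitro on an aromatic carbon, or a benzyl group on the sulfonyl sulfur, would bring the number down by more than the scatter.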